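The compounds below may be only part of what the source reports. "The series", "measured", "known", "first", "only" and "open" are said of these compounds alone.

Measured compounds:
compound 1 `CCCCOC(=O)NS(=O)(=O)c1ccc(CCC)cc1-c1ccc(Cn2c(Cc3ccccc3)nc3ccccc32)cc1` — 15 nM
compound 2 `CCCCOC(=O)NS(=O)(=O)c1ccc(CCC)cc1-c1ccc(Cn2c(C3CCC3)nc3ccccc32)cc1` — 12 nM

In an assay on membranes from HEK293 cells for displacement of a labelled ligand from Type-2 angiotensin II receptor (Homo sapiens), read by radioligand binding (on this read-out lower numbers stand for stronger inhibition and higher numbers for weaker inhibition), compound 1 gives 15 nM and compound 2 gives 12 nM. The two values lie within the scatter of each other, as the step of a 1.3-fold lower number from compound 1 to compound 2 (0.10 log units; within the scatter) shows; compound 2 cannot be set apart from compound 1 on these numbers.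

Compound 3 `CCCCOC(=O)NS(=O)(=O)c1ccc(CCC)cc1-c1ccc(Cn2c(C3CCCC3)nc3ccccc32)cc1` carries the change (cyclopentyl in place of cyclobutyl on an aromatic carbon). For the measured compounds named here, the only measured step that touches this position is the one from compound 1 to compound 2, where a benzyl gave way to a cyclobutyl without a shift beyond the scatter, a 1.3-fold lower number from compound 1 to compound 2 (0.10 log units; within the scatter). That exchange was considerably larger than the present one, and still the number barely moved, so for compound 3 no step beyond the scatter is expected in this assay in either direction.

On this basis compound 3 is estimated at 12 nM, with a range from 5 nM to 30 nM, the expected step from compound 2 being no change at the digits printed from compound 2 to compound 3 (within the scatter).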

Compound 3, inhibition constant: 35 nM
Compound 3: middle estimate off by 2.9-fold (0.46 log units), on the low side; measured number outside the range, above it.
By their numbers in this assay, from the lowest: compounds 2 and 1 (each within the scatter of the next); then compound 3.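

In this assay the aromatic carbon between two ring nitrogen atoms proves sensitive to the group it carries: the exchange of cyclobutyl for cyclopentyl, a change from a four-membered to a five-membered non-aromatic ring, gives a step beyond the scatter (a 2.9-fold higher number from compound 2 to compound 3 (0.46 log units; beyond the scatter)). Cyclopentyl also separates from benzyl, again beyond the scatter (a 2.3-fold higher number from compound 1 to compound 3 (0.37 log units; beyond the scatter)), so the earlier agreement between benzyl and cyclobutyl (a 1.3-fold lower number from compound 1 to compound 2 (0.10 log units; within the scatter)) does not extend to every carbon group at this place, and compound 1, with its larger benzyl, goes against any reading in which group size alone raises the number. Nothing available explains why cyclopentyl stands apart from the other two groups.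

As far as these compounds go, three groups at one position do not define a trend, so it remains open whether cyclopropyl or cyclohexyl would fall with cyclobutyl or with cyclopentyl. From the compounds shown here alone, it also remains open how an open chain such as n-butyl, or a group carrying nitrogen or oxygen such as an amine or a methoxymethyl, would read here, and whether the step from cyclobutyl to cyclopentyl would persist on a different shared core.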